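A Dimethylamino Group on the Shared Core

A few compounds are considered here, and "the series" means these few. Any claim that something is new, unique, unknown or untested is made for them only; others in the source may bear on it.

Compound 1 `COc1ccc(/C=C/c2ccc3ccccc3c2)cc1`: > 5000 nM (a limit)
Compound 2 `FC(F)(F)c1ccc(/C=C/c2ccc3ccccc3c2)cc1`: > 5000 nM (a limit)

In a functional assay on P388 cells (Mus musculus) for inhibition (on this read-out lower numbers stand for stronger inhibition and higher numbers for weaker inhibition), compound 2 gives > 5000 nM, which is a limit and not a number. Compound 3 `CN(C)c1ccc(/C=C/c2ccc3ccccc3c2)cc1` has not yet been measured. It differs from compound 2 as follows: dimethylamino in place of trifluoromethyl on an aromatic carbon. In words, dimethylamino stands in place of trifluoromethyl on an aromatic carbon, para to a large group.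

For the measured compounds named here, the one measured step that bears on this change is a step that the two limits leave unreadable from compound 1 to compound 2. It therefore gives neither a size nor a direction. Going by the values given here, the only other guide is the limit of > 5000 nM in this assay, at which 2 of the 2 values shown sit. On that slender basis, no clear step beyond the scatter is expected, and compound 3 would most likely also be reported as a limit in this assay. The expected step is a step that the limit leaves unreadable from compound 2 to compound 3. Compound 3 is estimated at 6000 nM, with an expected range from 1500 nM to 20000 nM.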

Compound 3, half-maximal inhibitory concentration: 3660 nM
Estimate against measurement, compound 3: 1.6-fold (0.21 log units) above; measured number inside the range.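

With dimethylamino on an aromatic carbon, para to a large group, compound 3 gives 3660 nM in this assay, the only value among the compounds shown that is a number and not a limit. Set against trifluoromethyl, this change gives an at least 1.3-fold lower number from compound 2 to compound 3 (0.13 log units; that floor lies within the scatter), and set against methoxy, it gives an at least 1.3-fold lower number from compound 1 to compound 3 (0.13 log units; that floor lies within the scatter), so each step has a known floor, but that floor alone does not establish a step beyond the scatter. Compound 1 and compound 2 remain limits, and the step between them cannot be read: the limit of > 5000 nM in this assay, at which 2 of the 3 values shown sit.

The compounds shown leave open how large these two steps really are. They also leave open whether a primary amine, a hydroxyl or diethylamino at this position would give a number like that of compound 3.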